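The source may report more compounds than this note shows. Statements on the series, on what has been measured and on what is new or still open speak of the compounds shown alone.

Measured in a functional assay on U2OS cells (Homo sapiens) for cytotoxicity, read by MTT assay, with a stated time of 48 h; on this read-out lower numbers stand for stronger inhibition and higher numbers for weaker inhibition:
- Compound 1 `Fc1cccc(Nc2nc(-c3cccc(F)c3)nc3ccc(F)cc23)c1`: 49600 nM
- Compound 2 `Fc1cccc(-c2nc(Nc3ccccc3Cl)c3cc(F)ccc3n2)c1`: > 50000 nM (a limit)
- Compound 3 `Fc1cccc(-c2nc(Nc3cccc(Br)c3)c3cc(F)ccc3n2)c1`: > 50000 nM (a limit)

Compound 3 stands at a limit and has no number: > 50000 nM. The series as a whole shows (the limit of > 50000 nM in this assay, at which 2 of the 3 values shown sit).

Compound 4 `Oc1ccc(Nc2nc(-c3cccc(F)c3)nc3ccc(F)cc23)cc1` has not been measured. Compared with compound 3, it carries 4-hydroxyphenyl in place of 3-bromophenyl on a nitrogen on an aromatic ring.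

For the measured compounds named here, three measured steps bear on this change, all of them in the same group on that nitrogen: a number no lower from compound 1 to compound 2 (the limit leaves the size open), a number no lower from compound 1 to compound 3 (the limit leaves the size open) and a step that the two limits leave unreadable from compound 2 to compound 3. Going by the values given here, none has a readable size, so they set no scale for a step in this assay. Among the compounds with values here, no measured compound carries the 4-hydroxyphenyl group, so the entering group is untested. Within the data shown here, the only number available is compound 1 at 49600 nM, and the expectation rests on that value. A small move towards stronger inhibition is expected, with a substantial chance that the result stays at the limit.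

The expected step is an at least 1.4-fold lower number from compound 3 to compound 4 (0.15 log units; that floor lies within the scatter).

For compound 4 the estimated value is 35000 nM, with an expected range of 9000 nM to 70000 nM.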

Compound 4, half-maximal inhibitory concentration: > 50000 nM
Compound 4 gave a limit, no number; the forecaster's own chance of this, stated with the estimate: 45%; at least 1.4-fold (0.15 log units) between middle value and limit.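

In this assay compound 4 gives > 50000 nM, which is a limit and not a number. For the compounds shown here, the one new step with a direction is a number no lower from compound 1 to compound 4 (the limit leaves the size open), and the steps among the limit compounds cannot be read. On this nitrogen, 4-hydroxyphenyl, with its hydrogen-bond donor and acceptor, now sits with 3-bromophenyl and 2-chlorophenyl, so adding these features to the ring gives no reading below the ceiling of the assay: the limit of > 50000 nM in this assay, at which 3 of the 4 values shown sit.

The compounds shown leave open whether any group on this nitrogen can give a readable number well clear of that ceiling, for example a ring bearing an amine or a carboxylic acid, or a longer chain in place of the ring. They also leave open how far the value depends on the 3-fluorophenyl group on the core, since that group is the same in all the compounds shown.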